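The source may hold more compounds than are shown below. What is called first, only, known or untested is meant among the compounds shown, and "the series" means these compounds.

Working notes on the series.

Three compounds have numbers in a functional assay on HeLa cells for antagonist activity at 5-hydroxytryptamine receptor 6 (Homo sapiens); on this read-out lower numbers stand for stronger inhibition and higher numbers for weaker inhibition. Compound 1 `CCn1nc(S(=O)(=O)c2cccc3ccccc23)c2cc(N3CCN(C)CC3)ccc21` gives 1.7 nM and compound 3 `CCCn1nc(S(=O)(=O)c2cccc3ccccc23)c2cc(N3CCNCC3)ccc21` gives 2.2 nM; these two values sit within the scatter of each other, so no order between them is claimed. Compound 2 `CN1CCN(c2ccc3[nH]nc(S(=O)(=O)c4ccccc4Cl)c3c2)CC1` gives 101 nM, the highest of the three numbers, beyond the scatter from both compound 1 and compound 3. Among the measured compounds shown here, compound 2 thus stands clearly apart as the weaker inhibitor among the measured set, and no single-point step between measured compounds is available to connect it to the other two.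

Compound 4 `CN1CCN(c2ccc3[nH]nc(S(=O)(=O)c4ccc(Cl)cc4)c3c2)CC1` remains to be measured. It differs from compound 2 by 4-chlorophenyl in place of 2-chlorophenyl on a sulfonyl sulfur; the atoms are the same and only the ring attachment differs. For the measured compounds named here, no measured pair shows this kind of change, so the expectation rests on compound 2 alone. Compound 4 is expected to stay close to compound 2, with a small step of a 1.5-fold higher number from compound 2 to compound 4 (0.17 log units; within the scatter) toward a slightly higher number, possibly within the scatter. The estimate for compound 4 in this assay is 150 nM, with a range from 40 nM to 600 nM.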

Compound 4, half-maximal inhibitory concentration: 108 nM
Compound 4: the middle estimate sits 1.4-fold (0.14 log units) above what was measured; the range from low to high includes it.
By their numbers in this assay, from the lowest: compounds 1 and 3 (each within the scatter of the next); then compounds 2 and 4 (each within the scatter of the next).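

In this assay, 4-chlorophenyl in place of 2-chlorophenyl on a sulfonyl sulfur gives a 1.1-fold higher number from compound 2 to compound 4 (0.03 log units; within the scatter), so the two attachments cannot be told apart on this read-out. Among the compounds shown here, this is the first pair that differs in one place, and it shows that, on the core of compound 2, this change of ring attachment leaves the number within the scatter. Nothing at hand offers a reason for this result.

Compound 2 and compound 4 each differ from compound 1 and compound 3 in more than one place, so the large gap between these groups cannot be assigned to any single change. Going by these compounds, it also remains open whether methoxy or trifluoromethyl in place of the chlorine on this phenyl ring would keep the number in the same range.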